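This account rests on a few compounds, and the source may have more. Where it says the series, first, only, none or still open, it means among the compounds named here.

Measured in a functional assay on A549 cells (Homo sapiens) for inhibition, read by CCK-8 assay; a lower number here means a stronger inhibitor, a higher number a weaker inhibitor:
compound 1 `Oc1ccccc1/C=N/c1nnc(SCc2nnc(-c3ccccc3)o2)s1` gives 4110 nM;
compound 2 `Oc1ccccc1/C=N/c1nnc(SCc2nnc(-c3ccc(Br)cc3)o2)s1` gives 20000 nM;
compound 3 `Cc1cccc(-c2nnc(CSc3nnc(/N=C/c4ccccc4O)s3)o2)c1` gives 24300 nM.

Compound 3 has the highest number of the three; its gap to compound 2 lies within the scatter, whereas a 5.9-fold higher number from compound 1 to compound 3 (0.77 log units; beyond the scatter) lies beyond it. Compound 4 `O=[N+]([O-])c1cccc(-c2nnc(CSc3nnc(/N=C/c4ccccc4O)s3)o2)c1` differs from compound 3 by nitro in place of methyl on an aromatic carbon. Among the measured compounds shown here, no measured step swaps one group on that phenyl for another of a different kind. For the measured compounds named here, the steps that bear on the position are a 4.9-fold higher number from compound 1 to compound 2 (0.69 log units; beyond the scatter) and a 5.9-fold higher number from compound 1 to compound 3 (0.77 log units; beyond the scatter), both adding a group to the phenyl and both modest, while a 1.2-fold higher number from compound 2 to compound 3 (0.08 log units; within the scatter) shows two different groups within the scatter of each other. A nitro in place of methyl is therefore expected to leave the number roughly where it stands, with a 1.2-fold lower number from compound 3 to compound 4 (0.08 log units; within the scatter) within the scatter. Compound 4 is estimated at 20000 nM, range 8000 nM to 50000 nM.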

Compound 4, half-maximal inhibitory concentration: 36900 nM
Compound 4: the middle estimate sits 1.8-fold (0.27 log units) below what was measured, and the stated range covers the measured number.
By their numbers in this assay, from the lowest: compound 1; then compounds 2, 3 and 4 (each within the scatter of the next).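

In this assay, nitro in place of methyl on this phenyl (a 1.5-fold higher number from compound 3 to compound 4 (0.18 log units; within the scatter)) and 3-nitrophenyl in place of 4-bromophenyl (a 1.8-fold higher number from compound 2 to compound 4 (0.27 log units; within the scatter)) both stay within the scatter, so compounds 2, 3 and 4 now read alike across three different groups. Nitro in place of hydrogen (a 9.0-fold higher number from compound 1 to compound 4 (0.95 log units; beyond the scatter)) lies beyond the scatter, so the nitro compound also parts from compound 1, as the bromo and methyl compounds do. No measured evidence accounts for this shared shift.

As far as these compounds go, whether an amine or a carboxylic acid on this phenyl would stay with compounds 2, 3 and 4 or come nearer to compound 1 remains open. Also open, from the compounds shown here alone, is whether 4-nitrophenyl would read like 3-nitrophenyl.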